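The source may hold more compounds than are shown below. What is called first, only, known or untested is meant among the compounds shown, and "the series" means these compounds.

Measured compounds:
compound 1 `Cc1csc(N)c1C(=O)c1ccc(Cl)cc1`, 1%
compound 2 `CC(C)(C)Cc1c(-c2ccoc2)sc(N)c1C(=O)c1ccc(Cl)cc1`, 1%

In an assay on CHO cells for displacement of a labelled ligand from adenosine receptor A3 (Homo sapiens), read by scintillation counting, tested at 10 uM (a higher number here means more inhibition at the concentration tested (going by the name of the read-out), a lower number less inhibition), compound 1 gives 1%. Compound 2 `CC(C)(C)Cc1c(-c2ccoc2)sc(N)c1C(=O)c1ccc(Cl)cc1` carries a neopentyl group and a furan-3-yl group on the shared core and in this assay compound 2 gives 1%, level with compound 1 at the digits shown, so the two readings sit within the scatter of each other and show no order.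

Compound 3 `Cc1cccc(-c2sc(N)c(C(=O)c3ccc(Cl)cc3)c2CC(C)(C)C)c1` is the next step from compound 2: 3-methylphenyl in place of furan-3-yl on an aromatic carbon. The group that leaves sits next to the ring sulfur and next to the ring atom that bears the neopentyl group. Both measured compounds show essentially no inhibition at the concentration tested, and nothing in the numbers points to a gain from this swap, so the step is expected to stay within the scatter: a number 2 percentage points higher from compound 2 to compound 3 (within the scatter). For compound 3 in this assay the estimate is 3%, within -8% to 15%.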

Compound 3, a percentage reported as inhibition, at one concentration (the size of the read-out at that concentration, not a potency): 1%
Estimate against measurement, compound 3: 2 percentage points above; low and high end bracket the measured number.
By their numbers in this assay, from the lowest: compounds 1, 2 and 3 (each within the scatter of the next).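

In this assay, the step of no change at the digits printed from compound 2 to compound 3 (within the scatter) comes with 3-methylphenyl in place of furan-3-yl on the aromatic carbon next to the ring sulfur. At this position, then, a six-membered aromatic ring of carbon only, with its methyl group, reads the same as a five-membered aromatic ring with one hetero atom, and the hydrogen-bond acceptor counted for furan-3-yl leaves no mark on the number. Nothing available here offers an explanation for this reading.

Still open, going by these compounds, is whether any group on this carbon can move the number beyond the scatter, as this single swap of one aromatic ring for another does not. A carboxylic acid or an aminomethyl group here would test a group that is not an aromatic ring, and a shorter chain in place of the neopentyl group would probe the neighbouring ring atom.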